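The source may hold more compounds than are shown below. What is called first, only, known or untested is meant among the compounds shown, and "the series" means these compounds.

Compound 1 `O=c1[nH]cnc2c1c(-c1cccs1)cn2[C@@H]1O[C@H](CO)[C@@H](O)[C@H]1O`: > 20000 nM
Compound 2 `Cc1nc(N)c2c(-c3ccco3)cn([C@@H]3O[C@H](CO)[C@@H](O)[C@H]3O)c2n1`: > 20000 nM

In a functional assay on HCT-116 cells (Homo sapiens), read by MTT assay, with a stated time of 72 h (on this read-out lower numbers stand for stronger inhibition and higher numbers for weaker inhibition), compound 2 gives > 20000 nM, which is a limit of the assay and not a number. Compound 1 likewise gives only a limit, > 20000 nM. Among the measured compounds shown here, both values sit at the same point (the limit of > 20000 nM in this assay, at which 2 of the 2 values shown sit), so no step between measured compounds can be read from them. Compound 3 `Cc1nc(N)c2c(-c3ccsc3)cn([C@@H]3O[C@H](CO)[C@@H](O)[C@H]3O)c2n1` differs from compound 2 by thiophen-3-yl in place of furan-2-yl on an aromatic carbon. For the measured compounds named here, with no measured step to lean on, the change is expected to bring no step beyond the scatter a step that the limit leaves unreadable from compound 2 to compound 3. Compound 3 is therefore expected to stay at a limit, with an estimate of 30000 nM and a range from 10000 nM to 100000 nM.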

Compound 3, half-maximal inhibitory concentration: > 20000 nM
Compound 3 was reported as a limit; the forecaster's own chance of this, stated with the estimate: 85%; the middle value is on the limit's open side.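

Compound 3 gives > 20000 nM, which is a limit and not a number, so no step from compound 2 to compound 3 can be read: the limit of > 20000 nM in this assay, at which 3 of the 3 values shown sit.

The compounds shown leave open whether thiophen-3-yl and furan-2-yl differ at all in this assay.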